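The source may report more compounds than this note shows. Statements on the series, on what has been measured and on what is new or still open speak of the compounds shown alone.

Three members of the series have numbers in an assay on HEK293 cells for positive allosteric modulation of metabotropic glutamate receptor 2 (Rattus norvegicus), read by thallium flux, with a stated time of 2.5 min; a lower number here means that less compound is needed, a higher number that more compound is needed for the effect. Compound 1 `Cc1c(OCCCCOc2ccccc2C(=O)O)ccc(C(=O)CC2CCCC2)c1O` gives 335 nM, compound 2 `CCCC(=O)c1ccc(OCCCCOc2cccc(C(=O)O)c2C)c(C)c1O` gives 52 nM, and compound 3 `Cc1c(OCCCCOc2ccc(C(=O)C(C)C)c(O)c2C)cccc1C(=O)O` gives 149 nM, so compound 3 stands second highest of the three, closer to compound 1 than to compound 2. For the measured compounds named here, the one single-point step measured so far is a 2.9-fold higher number from compound 2 to compound 3 (0.46 log units; beyond the scatter), where branching entered the chain on the carbonyl carbon. Compound 4 `CCC(=O)c1ccc(OCCCCOc2cccc(C(=O)O)c2C)c(C)c1O` differs from compound 3 by hydrogen in place of methyl on a saturated chain carbon bound to a carbonyl carbon and a saturated chain carbon, isopropylcarbonyl becoming propanoyl, an unbranched chain again. Going by the values given here, that measured step is the only guide, and it points to a lower number for an unbranched chain, of modest size. Compound 4 is therefore expected to give about 70 nM, in the range 30 nM to 170 nM. The expected step is a 2.1-fold lower number from compound 3 to compound 4 (0.33 log units; beyond the scatter).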

Compound 4, half-maximal effective concentration: 62 nM
The estimate for compound 4 lay 1.1-fold (0.05 log units) above the measured number; the measured number falls inside the stated range.
By their numbers in this assay, from the lowest: compounds 2 and 4 (each within the scatter of the next); then compound 3; then compound 1.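

In this assay, hydrogen in place of methyl on the chain carbon bound to the carbonyl carbon gives a 2.4-fold lower number from compound 3 to compound 4 (0.38 log units; beyond the scatter), so removing the branch from either side of compound 3's chain is now seen from a second unbranched partner. The same exchange two bonds along the chain from the carbonyl carbon gives a 1.2-fold higher number from compound 2 to compound 4 (0.08 log units; within the scatter), so among compounds 2, 3 and 4 the methyl counts only where it forms the isopropyl branch. Nothing shown gives a reason for this difference. The compounds shown leave open how acetyl or pentanoyl would read on this core.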